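Working notes: ethyl urea analogue in the cytotoxicity screen

The source may report more compounds than this note shows. Statements on the series, on what has been measured and on what is new or still open speak of the compounds shown alone.

Measured compounds:
- Compound 1 `Cc1cn([C@@H]2O[C@H](CO[Si](C)(C)C(C)(C)C)[C@@]3(OS(=O)(=O)C=C3NC(=O)NC(=O)c3ccccc3)[C@H]2O[Si](C)(C)C(C)(C)C(C)C)c(=O)n(C)c1=O` gives in an ADME assay on HEL cells (Homo sapiens) for cytotoxicity, with a stated time of 3 days (on this read-out higher numbers stand for lower toxicity in this test and lower numbers for higher toxicity in this test), only the limit >= 100000 nM.
- Compound 2 `Cc1cn([C@@H]2O[C@H](CO[Si](C)(C)C(C)(C)C(C)C)[C@@]3(OS(=O)(=O)C=C3NC(=O)NC(=O)c3ccccc3)[C@H]2O[Si](C)(C)C(C)(C)C(C)C)c(=O)n(C)c1=O` gives in this assay only the limit >= 100000 nM.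
- Compound 3 `Cc1cn([C@@H]2O[C@H](CO[Si](C)(C)C(C)(C)C)[C@@]3(OS(=O)(=O)C=C3NC(=O)NCc3ccccc3)[C@H]2O[Si](C)(C)C(C)(C)C)c(=O)n(C)c1=O` gives in this assay the value 4000 nM.

Among the measured compounds shown here, compound 3 is the only member with a number; the other two values are limits, as the limit of >= 100000 nM in this assay, at which 2 of the 3 values shown sit, records. For the measured compounds named here, the one measured step, a step that the two limits leave unreadable from compound 1 to compound 2, cannot be read because both ends are limits, so it carries no information on size.

Compound 4 `CCNC(=O)NC1=CS(=O)(=O)O[C@@]12[C@@H](CO[Si](C)(C)C(C)(C)C)O[C@@H](n1cc(C)c(=O)n(C)c1=O)[C@@H]2O[Si](C)(C)C(C)(C)C` differs from compound 3 by methyl in place of phenyl on a saturated chain carbon bound to an amide-type nitrogen. Going by the values given here, no measured step touches this change; the benzoyl-bearing compounds 1 and 2 differ from compound 3 at the same position but in a different way and only as limits. The expectation for compound 4 therefore rests on compound 3 alone, with wide uncertainty: a step of a 2.5-fold higher number from compound 3 to compound 4 (0.40 log units; beyond the scatter) is estimated, and compound 4 is expected to fall near 10000 nM, between 2000 nM and 100000 nM, with a fair chance that only a limit is reported.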

Compound 4, minimum cytotoxic concentration: >= 3200 nM
Compound 4: a limit, no number; the forecaster's own chance of this, stated with the estimate: 35%; the middle value does not contradict the limit.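

In this assay compound 4 gives only the limit >= 3200 nM and no number, so the step from compound 3 to compound 4 cannot be read. The compounds shown leave open whether ethyl in place of benzyl changes the minimum cytotoxic concentration, and in which direction.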